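The compounds below may be only part of what the source reports. "The series", "measured", "known", "first", "only" and "open" are said of these compounds alone.

The measured compounds:
Compound 1, `CCN1C(=O)CN(S(=O)(=O)c2ccc(-n3nc(C(=O)O)cc3C)cc2)C1=S`, in a functional assay on the whole organism (blood, strain albino) with Mus musculus as the target, with stated times of 6 days and 4 h, at a dose of 1 mmol/kg by the oral route (on this read-out lower numbers stand for less inhibition and higher numbers for more inhibition at the one dose given (going by the name of the read-out)), gives < 1%, which is a limit of the assay and not a number.
Compound 2, `CCN1C(=O)CN(S(=O)(=O)c2ccc(-n3nc(C)cc3C)cc2)C1=S`, in this assay gives < 1%, likewise a limit.
Compound 3, `Cc1cc(C)n(-c2ccc(S(=O)(=O)N3CC(=O)N(c4ccccc4)C3=S)cc2)n1`, in this assay gives 8%.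

Compound 1 thus stands at the floor of what this assay reports, a position it shares with compound 2; (the limit of < 1% in this assay, at which 2 of the 3 values shown sit). The step that the two limits leave unreadable from compound 1 to compound 2 is therefore unreadable. Among the compounds with values here, the one step that can be read, a number at least 7 percentage points higher from compound 2 to compound 3 (that floor lies within the scatter), comes from phenyl in place of ethyl on the ring nitrogen and stays at a size no larger than the scatter.

Compound 4, `Cc1cc(C(=O)O)nn1-c1ccc(S(=O)(=O)N2CC(=O)N(Cc3ccccc3)C2=S)cc1`, differs from compound 1 by phenyl in place of methyl on a saturated chain carbon bound to an amide-type nitrogen in a ring. The nearest measured step is that from compound 2 to compound 3, which places a phenyl in the same region of the core, and it gave only a small rise. Compound 4 is therefore expected to show a step of a number at least 4 percentage points higher from compound 1 to compound 4 (that floor lies within the scatter) that does not clearly exceed the scatter. The estimate for compound 4 in this assay is 5%, with a range from 0% to 15%.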

Compound 4, a percentage reported as inhibition, in the whole organism at one dose (the size of the read-out at that dose, not a potency): < 1%
Compound 4 gave a limit, no number (the forecaster's own chance of this, stated with the estimate: 40%); at least 4 percentage points between middle value and limit.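

Compound 4 gives < 1% in this assay, a limit and not a number. Compound 1 and compound 4 thus both sit at a limit, so no step between them can be read: the limit of < 1% in this assay, at which 3 of the 4 values shown sit.

The compounds shown leave open whether ethyl to benzyl changes the inhibition at all.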